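The source may hold more compounds than are shown below. What is called first, only, known or untested is meant among the compounds shown, and "the series" means these compounds.

Series notes. In a functional assay on isolated protein for inhibition of Glucose-dependent insulinotropic receptor (Rattus norvegicus), read by HTRF and cAMP accumulation (on this read-out lower numbers stand for an effect already at smaller amounts and higher numbers for an effect only at larger amounts of compound), compound 1 `Cc1nc(S(C)(=O)=O)ccc1Oc1ncnc(OC2CCN(C(=O)SC3CCC3)CC2)c1F` gives 77.4 nM. Compound 2 `Cc1nc(S(C)(=O)=O)ccc1Oc1ncnc(OC2CCN(C(=S)OC3(C)CC3)CC2)c1F` gives 48.8 nM in this assay. Compound 3 `CCC(F)(F)C(=O)N1CCC(Oc2ncnc(Oc3ccc(S(C)(=O)=O)nc3C)c2F)CC1` gives 69.2 nM in this assay and so stands second highest of the three numbers, nearest to compound 1 and furthest from compound 2, both gaps within the scatter. Compound 4 `Cc1nc(S(C)(=O)=O)ccc1Oc1ncnc(OC2CCN(C(=O)c3nc(C(C)(C)F)no3)CC2)c1F` carries a group of 9 heavy atoms (5 carbon, 2 nitrogen, 1 oxygen, 1 fluorine; one five-membered aromatic ring with 3 hetero atoms) in place of a group of 5 heavy atoms (3 carbon, 2 fluorine; no ring), on a carbonyl carbon. The steps touching this position are a 1.1-fold lower number from compound 1 to compound 3 (0.05 log units; within the scatter) and a 1.4-fold higher number from compound 2 to compound 3 (0.15 log units; within the scatter), with the remaining pair giving a 1.6-fold lower number from compound 1 to compound 2 (0.20 log units; within the scatter); each exchange of the group on the carbonyl carbon has left the number within the scatter. Compound 4 is therefore expected to show a 1.1-fold lower number from compound 3 to compound 4 (0.03 log units; within the scatter), nothing beyond the scatter. For compound 4 the estimate is 65 nM, ranging from 20 nM to 200 nM.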

Compound 4, half-maximal effective concentration: 606 nM
The estimate for compound 4 lay 9.3-fold (0.97 log units) below the measured number; measured number above the stated range.
By their numbers in this assay, from the lowest: compounds 2, 3 and 1 (each within the scatter of the next); then compound 4.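

On the carbonyl carbon, the five-membered aromatic ring with 3 hetero atoms gives the only exchange shown that goes beyond the scatter in this assay: an 8.8-fold higher number from compound 3 to compound 4 (0.94 log units; beyond the scatter) and a 7.8-fold higher number from compound 1 to compound 4 (0.89 log units; beyond the scatter). The same holds against the group on the amine nitrogen in a ring of compound 2, with a 12-fold higher number from compound 2 to compound 4 (1.09 log units; beyond the scatter), so this position does not accept every group equally. No measurement at hand bears on the reason for these steps.

Going by these compounds, it remains open whether the steps follow the aromatic ring or the larger heavy-atom count of the entering group. A phenyl or a tert-butyl on the same carbonyl carbon would help to separate the two.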